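Series notes: adrenergic binding, phenyl to butyl swap

The compounds below may be only part of what the source reports. "The series", "measured", "known", "first", "only" and "open" are said of these compounds alone.

Measured so far:
compound 1, `CN1CCC[C@@H]1Cn1nc(Cc2ccc(F)c(F)c2)c2ccccc2c1=O`: 200 nM
compound 2, `O=c1c2ccccc2c(Cc2ccc(Cl)cc2)nn1C[C@H]1CCCN1CCCCCc1ccc(OCCCN2CCCCCC2)cc1`: 25.1 nM

In an assay for binding affinity to Alpha-1A adrenergic receptor (Homo sapiens) (on this read-out lower numbers stand for stronger inhibition and higher numbers for weaker inhibition), compound 1 stands at the highest of the two numbers; compound 2 gives a lower reading, a gap that lies beyond the scatter. Compound 3, `CCCCCc1nn(C[C@H]2CCCN2C)c(=O)c2ccccc12`, is not yet measured. Relative to compound 1 it carries butyl in place of 3,4-difluorophenyl on a saturated chain carbon bound to an aromatic carbon. Within the data shown here, no step of this kind is recorded among the measured compounds, so the expectation rests on judgement alone: a modest shift toward weaker binding is expected, about a 3.0-fold higher number from compound 1 to compound 3 (0.48 log units; beyond the scatter). Compound 3 is therefore estimated at 600 nM, with a range of 150 nM to 2500 nM.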

Compound 3, inhibition constant: 501 nM
Compound 3: the middle estimate sits 1.2-fold (0.08 log units) above what was measured; low and high end bracket the measured number.
By their numbers in this assay, from the lowest: compound 2; then compound 1; then compound 3.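

In this assay, butyl in place of 3,4-difluorophenyl on a saturated chain carbon bound to an aromatic carbon gives a 2.5-fold higher number from compound 1 to compound 3 (0.40 log units; beyond the scatter) and so costs only modest binding. At this position, the aromatic ring and both fluorines can therefore leave together without abolishing the reading. No measurement at hand accounts for the step.

Going by these compounds, it remains open whether an unsubstituted phenyl would separate the effect of the ring from that of the fluorines. Also open, on these data alone, is how a longer chain or an amine at this position would read.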